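The source may report more compounds than this note shows. Statements on the series, on what has been measured and on what is new or still open speak of the compounds shown alone.

Compound 1 `O=C(NO)c1ccccc1Br` gives 270000 nM in an ADME assay on Huh-7 cells (Homo sapiens) for cytotoxicity, read by MTT assay, with a stated time of 72 h; on this read-out lower numbers stand for higher toxicity in this test and higher numbers for lower toxicity in this test; compound 2 `O=C(NO)c1ccccc1[N+](=O)[O-]` gives 55000 nM in this assay.

Going by the values given here, compound 2 stands lowest of the two numbers in this assay, with compound 1 the nearest, and the only measured step, a 4.9-fold lower number from compound 1 to compound 2 (0.69 log units; beyond the scatter), separates them. Compound 3 `CCCCOc1ccccc1C(=O)NO` differs from compound 2 as follows: butoxy in place of nitro on an aromatic carbon. Among the compounds with values here, no measured step compares butoxy with nitro at this place, so the step from compound 1 to compound 2 bears on it only in that it shows the nitro-bearing compound with the lower number of the two; removing the nitro is therefore expected to move the number back toward that of compound 1, without certainty as to size. The estimated step is a 3.6-fold higher number from compound 2 to compound 3 (0.56 log units; beyond the scatter), a modest rise beyond the scatter. Compound 3 is thus expected to give about 200000 nM in this assay, within a range from 60000 nM to 600000 nM.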

Compound 3, half-maximal cytotoxic concentration: 380000 nM
The estimate for compound 3 lay 1.9-fold (0.28 log units) below the measured number; measured number inside the range.
By their numbers in this assay, from the lowest: compound 2; then compounds 1 and 3 (each within the scatter of the next).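

In this assay, butoxy at this place, ortho to a hydroxycarbamoyl group, gives a 6.9-fold higher number from compound 2 to compound 3 (0.84 log units; beyond the scatter), so the low number of compound 2 does not carry over to this replacement of nitro. Butoxy and bromo are not told apart here, with a 1.4-fold higher number from compound 1 to compound 3 (0.15 log units; within the scatter), which leaves compound 2 alone beyond the scatter of the other two and shows that, of these three groups, only nitro stands apart at this place. Nothing given here accounts for either step.

On these data alone, whether the low number is particular to nitro or would also appear with another group at this place, such as an amine or a carboxylic acid, stays open. So does whether a longer chain than butoxy, or a shorter one such as methoxy, would stay level with compound 1 and compound 3.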